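Notes on aryl variation at the shared core

This account rests on a few compounds, and the source may have more. Where it says the series, first, only, none or still open, it means among the compounds named here.

Measured so far:
compound 1 `O=C(O)Cc1sc(C(c2ccc(F)cc2)c2ccc(F)cc2)nc1-c1ccnc(N2CCCC2)c1` — 80%
compound 2 `NS(=O)(=O)c1ccc(-c2nc(C(c3ccc(F)cc3)c3ccc(F)cc3)sc2CC(=O)O)cc1` — 80%

In an in vitro functional assay on HEK285-7 cells for antagonist activity at prostaglandin D2 receptor 2 (Homo sapiens), read by BRET and beta-arrestin recruitment (a higher number here means a larger maximal response, a lower number a smaller maximal response), compound 2 gives 80%, level with compound 1 at the digits shown; the step of no change at the digits printed from compound 1 to compound 2 (within the scatter) lies within the scatter, 4-sulfamoylphenyl in place of 2-(pyrrolidin-1-yl)pyridin-4-yl leaving the maximal response where it was. Compound 3 `O=C(O)Cc1sc(C(c2ccc(F)cc2)c2ccc(F)cc2)nc1-c1ccc(Cl)cc1` is not yet measured. It differs from compound 2 by chloro in place of sulfamoyl on an aromatic carbon, the same difference read one bond further out being 4-sulfamoylphenyl to 4-chlorophenyl. Going by the values given here, only one measured step bears on this, no change at the digits printed from compound 1 to compound 2 (within the scatter), and it exchanged the whole aryl group on the same aromatic carbon without moving the maximal response beyond the scatter. On that ground no step beyond the scatter is expected for compound 3 in this assay, and no change at the digits printed from compound 2 to compound 3 (within the scatter) is the estimated step. Compound 3 is therefore expected to give 80% in this assay, with a range of 60% to 95%. One supporting step is thin ground, so the range is set wide.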

Compound 3, largest response reached (reported as efficacy), in percent of the reference or control that the assay uses: 80%
The estimate for compound 3 equals the measured number at the digits printed; low and high end bracket the measured number.
By their numbers in this assay, from the lowest: compounds 1, 2 and 3 (each within the scatter of the next).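

In this assay the aryl position of the shared core now has a change confined to one substituent: chloro, a single heavy atom, stands in place of sulfamoyl on the aromatic carbon para to a large group, and the step reads no change at the digits printed from compound 2 to compound 3 (within the scatter) for this exchange. The exchange of the whole aryl group reads the same, no change at the digits printed from compound 1 to compound 3 (within the scatter) in the second direct comparison, so 2-(pyrrolidin-1-yl)pyridin-4-yl, 4-sulfamoylphenyl and 4-chlorophenyl do not separate on maximal response. No measurement offers an explanation for this flat reading.

As far as these compounds go, whether a primary amine, a carboxylic acid or a longer alkyl chain on this aromatic carbon would move the maximal response stays open. Also open, from the compounds shown here alone, is how far changes at other places on the shared core would do so.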